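Cytotoxicity notes on an oxalamide series: aryl swap

The compounds below may be only part of what the source reports. "The series", "measured", "known", "first", "only" and "open" are said of these compounds alone.

compound 1 `Cc1nc(C(NC(=O)C(=O)Nc2ccc(F)cc2F)C2CCCCN2)sc1CO` — > 87000 nM
compound 2 `Cc1nc(C(NC(=O)C(=O)Nc2ccc(F)cc2F)C2CCCCN2)sc1CCO` — > 84000 nM

Among the measured compounds shown here, both values so far in an ADME assay on TZM-b1 cells (Homo sapiens) for cytotoxicity, read by XTT assay, with a stated time of 3 days (on this read-out higher numbers stand for lower toxicity in this test and lower numbers for higher toxicity in this test), are limits of the assay rather than numbers. Compound 1 (`Cc1nc(C(NC(=O)C(=O)Nc2ccc(F)cc2F)C2CCCCN2)sc1CO`) reaches only a limit in this assay, namely > 87000 nM. Compound 2 (`Cc1nc(C(NC(=O)C(=O)Nc2ccc(F)cc2F)C2CCCCN2)sc1CCO`) likewise gives a limit in this assay, > 84000 nM. For the measured compounds named here, the single step between them, a step that the two limits leave unreadable from compound 1 to compound 2, cannot be read for size. Where compound 2 stands is known only as a limit (the limit of > 84000 nM in this assay, at which 1 of the 2 values shown sits), and compound 1 sits at the other limit (the limit of > 87000 nM in this assay, at which 1 of the 2 values shown sits).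

Compound 3 (`CC(=O)c1ccc(NC(=O)C(=O)NC(c2nc(C)c(CCO)s2)C2CCCCN2)cc1`) carries the next change: 4-acetylphenyl in place of 2,4-difluorophenyl on an amide-type nitrogen. Going by the values given here, no measured step bears on a change at this position, and the one step is unreadable, so no direction and no size can be drawn from the data for it. Compound 3 is expected to remain at or near the limit, estimated at 100000 nM with a range from 30000 nM to 300000 nM. The step this estimate implies, a step that the limit leaves unreadable from compound 2 to compound 3, is expected to lie within the usual scatter, a limit set against a limit.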

Compound 3, half-maximal cytotoxic concentration: > 77300 nM
Compound 3 gave a limit, no number; the forecaster's own chance of this, stated with the estimate: 75%; the middle value does not contradict the limit.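

Compound 3 gives only a limit in this assay, > 77300 nM. Compound 2 also stands at a limit, and the step from compound 2 to compound 3 cannot be read for size or direction. The compounds shown leave open where the actual cytotoxic concentrations of compound 1, compound 2 and compound 3 lie in this assay, and whether either change shifts them at all.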